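A few compounds are considered here, and "the series" means these few. Any claim that something is new, unique, unknown or untested is made for them only; others in the source may bear on it.

Three measured compounds share one core and differ only in the aryl group attached to the saturated chain carbon. Compound 1 `N=C(NCCCc1c[nH]cn1)NCCC(c1ccc(Cl)cc1)c1ccccn1` gives 0.8 in a functional assay on muscle tissue for agonist activity at histamine H2 receptor (Cavia porcellus) (on this read-out lower numbers stand for smaller maximal responses and higher numbers for larger maximal responses), compound 2 `N=C(NCCCc1c[nH]cn1)NCCC(c1ccc(C(F)(F)F)cc1)c1ccccn1` gives 0.9, and compound 3 `N=C(NCCCc1c[nH]cn1)NCCC(c1cccc(F)c1)c1ccccn1` gives 0.5. Compound 3 stands lowest of the three: the step a number 0.30 lower from compound 1 to compound 3 (beyond the scatter) and the step a number 0.40 lower from compound 2 to compound 3 (beyond the scatter) both run downward beyond the scatter, while the step a number 0.10 higher from compound 1 to compound 2 (within the scatter) stays within it.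

Compound 4 `N=C(NCCCc1c[nH]cn1)NCCC(c1ccc(Cl)c(Cl)c1)c1ccccn1` is not yet measured. Its change from compound 3 is 3,4-dichlorophenyl in place of 3-fluorophenyl on a saturated chain carbon bound to an aromatic carbon and a saturated chain carbon. Within the data shown here, the steps that bear on it are the two that replaced a 4-substituted phenyl with the 3-fluorophenyl, each lowering the response; reversing that direction, and again carrying a chloro at the 4-position, points to a rise back toward the level of compound 1. The step a number 0.30 higher from compound 3 to compound 4 (beyond the scatter) is therefore expected to be upward and beyond the scatter. For compound 4 the value in this assay is estimated at 0.8, between 0.6 and 1.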

Compound 4, intrinsic activity: the largest response reached, as a fraction of the reference agonist's: 0.8
Compound 4: the middle estimate sits on the measured number at the digits printed; measured number inside the range.
By their numbers in this assay, from the lowest: compound 3; then compounds 1, 4 and 2 (each within the scatter of the next).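

Adding a chloro to the 4-chlorophenyl ring leaves the response unmoved in this assay, with no change at the digits printed from compound 1 to compound 4 (within the scatter), so the saturated chain carbon tolerates the 3,4-dichlorophenyl as well as the ring with a single chloro. Against the 4-(trifluoromethyl)phenyl group the result is a number 0.10 lower from compound 2 to compound 4 (within the scatter), so these two rings cannot be told apart on this read-out. The low response seen with 3-fluorophenyl is not shared by the dichloro ring, with a number 0.30 higher from compound 3 to compound 4 (beyond the scatter), yet in that step fluoro gives way to chloro and a further chloro enters, so the rise cannot be pinned on either change alone.

Nothing shown explains why these rings differ. Still open, going by these compounds, is how a 3-chlorophenyl ring, or a methoxy group or an amine on this ring, would behave.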